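Isopropyl to trifluoromethyl on an aryl ether oxygen

The source may hold more compounds than are shown below. What is called first, only, known or untested is meant among the compounds shown, and "the series" means these compounds.

Compound 1, `CC(C)Oc1cccc(-c2ccc(C(=O)N(Cc3cccc(OCCCCCC(=O)O)c3)C(C)C)cc2)c1`, was tested in an ADME assay on Raji cells (Homo sapiens) for cytotoxicity, read by CellTiter-Glo and resazurin assay, with a stated time of 72 h; a higher number here means that more compound is needed for the effect, a lower number that less compound is needed. In this assay compound 1 gives > 26000 nM, which is a limit of the assay and not a measured number. Compound 2, `CC(C)N(Cc1cccc(OCCCCCC(=O)O)c1)C(=O)c1ccc(-c2cc3ccccc3n2S(=O)(=O)c2ccccc2)cc1`, carries the same core with a different group at one end. In this assay compound 2 likewise gives > 26000 nM, again a limit rather than a number. Going by the values given here, compound 1 therefore stands at the limit of > 26000 nM in this assay, at which 2 of the 2 values shown sit, together with every other value shown, so no step between measured compounds can be sized.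

Compound 3, `CC(C)N(Cc1cccc(OCCCCCC(=O)O)c1)C(=O)c1ccc(-c2cccc(OC(F)(F)F)c2)cc1`, differs from compound 1 by trifluoromethyl in place of isopropyl on an oxygen on an aromatic ring. Among the compounds with values here, no measured step is available to gauge this change. Because both measured values sit at the limit of > 26000 nM in this assay, at which 2 of the 2 values shown sit, the step from compound 1 to compound 3 is expected to be none beyond the scatter, and a step that the limit leaves unreadable from compound 1 to compound 3 is the expected size of that step. Compound 3 is estimated at 35000 nM in this assay, with an expected range from 15000 nM to 120000 nM, and the result will most likely again be reported only as a limit.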

Compound 3, half-maximal effective concentration: > 26000 nM
Compound 3 ended at the assay's limit (the forecaster's own chance of this, stated with the estimate: 80%); the middle value lies beyond the limit too.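

Compound 3 is again at a limit of this assay and not at a measured number, so the step from compound 1 to compound 3 cannot be read: the limit of > 26000 nM in this assay, at which 3 of the 3 values shown sit.

The compounds shown leave open how far each one lies from that limit, and which change to the shared core, if any, would give a measurable value in this assay.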